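This account rests on a few compounds, and the source may have more. Where it says the series, first, only, none or still open, it means among the compounds named here.

Measured compounds in a functional assay on HT-29 cells (Homo sapiens) for cytotoxicity, read by MTT assay, with a stated time of 72 h; on this read-out higher numbers stand for weaker inhibition and lower numbers for stronger inhibition:

compound 1, `O=C(Nc1ccc(Oc2ccncc2-c2cccnc2)c(F)c1)c1nn(-c2ccc(F)cc2)c(=O)c2ccccc12`, gives 990 nM
compound 2, `O=C(Nc1ccc(Oc2ccncc2-c2cccnc2)c(F)c1)c1nn(-c2ccc(Cl)cc2)c(=O)c2ccccc12`, gives 710 nM
compound 3, `O=C(Nc1ccc(Oc2ccncc2-c2cccnc2)c(F)c1)c1ccnn(-c2ccc(Cl)cc2)c1=O`, gives 4560 nM

Compounds 1 and 2 share a core and differ only by fluoro in place of chloro on an aromatic carbon; this change gives a 1.4-fold higher number from compound 2 to compound 1 (0.14 log units; within the scatter). Compound 3 carries a different core; the difference between the two cores is not broken down here. In this assay compound 3 stands with the highest number of the three, and its separation from both compound 1 and compound 2 lies beyond the scatter.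

Compound 4, `O=C(Nc1ccc(Oc2ccncc2-c2cccnc2)c(F)c1)c1ccnn(-c2ccc(F)cc2)c1=O`, is not yet measured. It differs from compound 3 by fluoro in place of chloro on an aromatic carbon, the same change as from compound 2 to compound 1, made on the core of compound 3 and at a place described in the same words. Among the measured compounds shown here, the only precedent is the step from compound 2 to compound 1, which lies within the scatter, so for compound 4 a step of a 1.3-fold higher number from compound 3 to compound 4 (0.12 log units; within the scatter) is expected, resting on a 1.4-fold higher number from compound 2 to compound 1 (0.14 log units; within the scatter). Compound 4 is therefore estimated at 6000 nM in this assay, with the range 3000 nM to 12000 nM expected to hold most repeats.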

Compound 4, half-maximal inhibitory concentration: 4770 nM
For compound 4 the middle estimate is 1.3-fold (0.10 log units) above the measured one, and the stated range covers the measured number.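

In this assay, going from 4-chlorophenyl to 4-fluorophenyl on the core of compound 3 gives a 1.0-fold higher number from compound 3 to compound 4 (0.02 log units; within the scatter) and no readable shift on this core. Set beside the earlier step, the change does not tell the two cores apart: the same change on two cores in this assay, a 1.4-fold higher number (0.14 log units; within the scatter) from compound 2 to compound 1 and a 1.0-fold higher number (0.02 log units; within the scatter) from compound 3 to compound 4, 1.3-fold (0.12 log units) apart, within the scatter of two such steps.
Among the compounds shown here, on these two cores the exchange of chloro for fluoro can therefore be carried across with the number staying within the scatter, but this rests on only two pairs in a single assay and does not show that the same would hold on a further core, or for any exchange larger than one halogen for another.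

Open, as far as these compounds go, is whether a group other than these two halogens at the same place on the aromatic ring, such as methoxy, an amine or a carboxylic acid, would give a step beyond the scatter in this assay. Also open, from the compounds shown here alone, is whether such a step, if there is one, would carry from one core to the other as the halogen exchange does.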